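A few compounds are considered here, and "the series" means these few. Any claim that something is new, unique, unknown or untested is made for them only; others in the source may bear on it.

Working notes on the series.

Of the compounds shown here, three have been measured in a functional assay on HeLa cells (Homo sapiens) for cytotoxicity, read by MTT assay, with a stated time of 72 h; on this read-out lower numbers stand for stronger inhibition and higher numbers for weaker inhibition. Compound 1 `O=C(c1ccccc1F)N(/N=N/c1ccc([N+](=O)[O-])cc1Cl)c1ccc([N+](=O)[O-])cc1Cl` gives 2350 nM in this assay. Compound 2 `O=C(c1ccccc1C(F)(F)F)N(/N=N/c1ccc([N+](=O)[O-])cc1Cl)c1ccc([N+](=O)[O-])cc1Cl` gives 10600 nM in this assay. Compound 3 `O=C(c1ccccc1F)N(/N=N/c1ccc([N+](=O)[O-])cc1C(F)(F)F)c1ccc([N+](=O)[O-])cc1C(F)(F)F` gives 800 nM in this assay, the lowest of the three numbers; its nearest neighbour is compound 1 and its furthest is compound 2, both gaps lying beyond the usual scatter of repeated measurements.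

Within the data shown here, the one single-point step among the measured compounds, (trifluoromethyl in place of fluoro on an aromatic carbon), gave a 4.5-fold higher number from compound 1 to compound 2 (0.65 log units; beyond the scatter). The difference between the core of compound 1 and the core of compound 3 is not broken down here.

Compound 4 `O=C(c1ccccc1C(F)(F)F)N(/N=N/c1ccc([N+](=O)[O-])cc1C(F)(F)F)c1ccc([N+](=O)[O-])cc1C(F)(F)F` is not yet measured in this assay. It relates to compound 3 exactly as compound 2 relates to compound 1: the change is trifluoromethyl in place of fluoro on an aromatic carbon, and the surroundings of the place are described in the same words in both cases, so it is taken as the same change made on a different core.

Among the measured compounds shown here, only one earlier example of the change exists, so the expectation rests on that single step. If the change behaves on the core of compound 3 as it did from compound 1 to compound 2, compound 4 is expected to show a 4.5-fold higher number from compound 3 to compound 4 (0.65 log units; beyond the scatter) in this assay, because the earlier step was a 4.5-fold higher number from compound 1 to compound 2 (0.65 log units; beyond the scatter). Compound 4 is therefore estimated at 3600 nM in this assay, with a range of 1500 nM to 9000 nM allowing for the change being read on a core for which it has not been tested before.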

Compound 4, half-maximal inhibitory concentration: 5350 nM
Compound 4: the middle estimate sits 1.5-fold (0.17 log units) below what was measured, and the stated range covers the measured number.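

In this assay, trifluoromethyl in place of fluoro on an aromatic carbon gave a 6.7-fold higher number from compound 3 to compound 4 (0.83 log units; beyond the scatter), and this step agrees with the earlier one in direction and, within the scatter, in size: the same change on two cores in this assay, a 4.5-fold higher number (0.65 log units; beyond the scatter) from compound 1 to compound 2 and a 6.7-fold higher number (0.83 log units; beyond the scatter) from compound 3 to compound 4, 1.5-fold (0.17 log units) apart, within the scatter of two such steps

Within these four compounds, the change therefore carries from the core of compound 1 to the core of compound 3 without a detectable difference in its effect on the cytotoxicity number. Among these compounds, this rests on only two pairs in a single cell assay, so it does not show that the change would behave alike on a further core or in another read-out, and it gives no explanation for the higher numbers.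

The compounds shown carry only 2-fluorophenyl or 2-(trifluoromethyl)phenyl on the carbonyl, which leaves open how an amine, a methoxy group or a carboxylic acid in that place would compare. The difference between the two cores also remains unresolved as a single-point change, so its separate contribution to the numbers cannot be read from these compounds.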